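Dimethylamino in place of acetoxy on the aromatic ring

The source may hold more compounds than are shown below. What is called first, only, known or untested is meant among the compounds shown, and "the series" means these compounds.

Measured so far:
compound 1 `COC(=O)C1=C(C)N=C(C)/C(=C(\O)OC)C1c1cccc(OC(C)=O)c1` — 6030 nM
compound 2 `COC(=O)C1=C(C)N=C(C)/C(=C(\O)OC)C1c1ccc(I)cc1` — 22900 nM

Both compounds were tested in a functional assay (muscle tissue) with Cavia porcellus as the target; on this read-out higher numbers stand for an effect only at larger amounts of compound and lower numbers for an effect already at smaller amounts. Compound 1 has the lowest of the two numbers; compound 2 stands apart from it by a gap beyond the usual scatter. Compound 3 `COC(=O)C1=C(C)N=C(C)/C(=C(\O)OC)C1c1cccc(N(C)C)c1` has not been measured. It differs from compound 1 in one place: dimethylamino in place of acetoxy on an aromatic carbon. Going by the values given here, no measured pair shows this change, so the expectation rests on compound 1 alone; a modest step toward a larger number is expected, about a 1.7-fold higher number from compound 1 to compound 3 (0.22 log units; within the scatter). Compound 3 is therefore estimated at roughly 10000 nM, with a range from 3000 nM to 35000 nM.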

Compound 3, half-maximal effective concentration: 891 nM
Compound 3: middle estimate off by 11-fold (1.05 log units), on the high side, outside the stated range (below it).
By their numbers in this assay, from the lowest: compound 3; then compound 1; then compound 2.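

At this aromatic carbon, meta to a large group, the choice of group clearly matters: in this assay, dimethylamino in place of acetoxy gives a 6.8-fold lower number from compound 1 to compound 3 (0.83 log units; beyond the scatter), and the piece's first single-change comparison. The acetoxy group is therefore not required for an effect at smaller amounts of compound. Nothing measured here explains this gain. On these data alone, whether it depends on the nitrogen of dimethylamino stays open, and a simple primary amine, a methoxy group or a longer chain on the same carbon would test this.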